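This account rests on a few compounds, and the source may have more. Where it says the series, first, only, none or still open, it means among the compounds named here.

Measured compounds:
- compound 1, `CN(Cc1ccc(OCCCNC(=N)N)cc1)c1nc2ccc(Oc3ccc(F)cc3)cc2s1`: 521000 nM
- compound 2, `N=C(N)NCCCOc1ccc(CNc2nc3ccc(Oc4ccc(F)cc4)cc3s2)cc1`: 288000 nM
- compound 3, `CN(C)CCCOc1ccc(CNc2nc3ccc(Oc4ccc(C#N)cc4)cc3s2)cc1`: 41000 nM

All three were run in an assay on cells for inhibition of Voltage-dependent T-type calcium channel subunit alpha-1H (Homo sapiens), read by FLIPR and calcium flux, with stated times of 600 s and 300 s; on this read-out higher numbers stand for weaker inhibition and lower numbers for stronger inhibition. Compound 2 and compound 1 share a core and differ in one place, (methyl in place of hydrogen on a nitrogen on an aromatic ring). The step is a 1.8-fold higher number from compound 2 to compound 1 (0.26 log units; within the scatter), so these two numbers cannot be told apart. Compound 3 carries a different core; the difference between the two cores is not broken down here. What the values show is that in this assay compound 3 gives 41000 nM, the lowest of the three numbers, whereas compound 2 gives 288000 nM and compound 1 gives 521000 nM.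

Compound 4, `CN(C)CCCOc1ccc(CN(C)c2nc3ccc(Oc4ccc(C#N)cc4)cc3s2)cc1`, has not been measured. It is related to compound 3 in the same way that compound 1 is related to compound 2: methyl in place of hydrogen on a nitrogen on an aromatic ring. The place lines for the two changes read the same word for word, so this is the same change, now made on the core of compound 3. Within the data shown here, the only precedent is the step from compound 2 to compound 1, which stayed within the scatter. The expectation is therefore that compound 4 sits close to compound 3, with the step estimated as a 1.5-fold higher number from compound 3 to compound 4 (0.17 log units; within the scatter), resting on a 1.8-fold higher number from compound 2 to compound 1 (0.26 log units; within the scatter). For compound 4 in this assay the estimate is 60000 nM, with a range from 25000 nM to 150000 nM, the width reflecting that the change has been seen only once and on a different core.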

Compound 4, half-maximal inhibitory concentration: 64000 nM
Estimate against measurement, compound 4: 1.1-fold (0.03 log units) below, within the range that was stated.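

In this assay, methyl in place of hydrogen on a nitrogen on an aromatic ring gives a 1.6-fold higher number from compound 3 to compound 4 (0.19 log units; within the scatter), so on the core of compound 3 the change leaves no difference that can be told from assay scatter. Set beside the earlier step, the change reads the same on both cores: the same change on two cores in this assay, a 1.8-fold higher number (0.26 log units; within the scatter) from compound 2 to compound 1 and a 1.6-fold higher number (0.19 log units; within the scatter) from compound 3 to compound 4, 1.2-fold (0.06 log units) apart, within the scatter of two such steps. This shows that, in the two matched pairs available, the change carries across without a step beyond the scatter and without a detectable difference between the cores, but it does not show that the methyl has no effect at all, that the same holds on any other core, or which of the several differences between the two cores matters, if any does.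

Still open, going by these compounds, is whether a larger group on the same nitrogen, such as ethyl, a longer chain or acetyl, would also stay within the scatter, as only hydrogen and methyl appear there in these compounds. Also open, on these data alone, is whether the methyl step would hold on a core carrying a carboxylic acid or a primary amine in place of the guanidine or dimethylamine group.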